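Swapping methoxy for tert-butyl in a cytotoxicity series

This account rests on a few compounds, and the source may have more. Where it says the series, first, only, none or still open, it means among the compounds named here.

Compound 1 `COc1ccc(/C=C2\CN(C)C/C(=C\c3ccccc3F)C2=O)cc1`: 18400 nM
Compound 2 `COc1ccc(/C=C2\CN(C)C/C(=C\c3ccccc3F)C2=O)cc1OC`: 18000 nM

Both compounds were tested in a functional assay on K562 cells (Homo sapiens) for cytotoxicity, read by MTT assay, with a stated time of 24 h; on this read-out higher numbers stand for weaker inhibition and lower numbers for stronger inhibition. Within the data shown here, compound 1 stands level with compound 2, the only other measured compound, as their two numbers lie within the scatter of each other. The next compound is compound 3 `CN1C/C(=C\c2ccc(C(C)(C)C)cc2)C(=O)/C(=C/c2ccccc2F)C1`, which keeps the core of compound 1 and changes one group: tert-butyl in place of methoxy on an aromatic carbon. In words, this is tert-butyl in place of methoxy on an aromatic carbon, para to a large group.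

Among the measured compounds shown here, only one measured step bears on this change, and only loosely: a 1.0-fold lower number from compound 1 to compound 2 (0.01 log units; within the scatter). In that step, methoxy took the place of hydrogen on an aromatic carbon of the same ring, and the number stayed within the scatter. For the measured compounds named here, no measured compound carries a tert-butyl group, so the data point in no firm direction. The expectation is therefore no step beyond the scatter in this assay, held with wide uncertainty. The estimated change is a 1.0-fold lower number from compound 1 to compound 3 (0.01 log units; within the scatter). Compound 3 is expected at 18000 nM, with an estimated range of 7000 nM to 40000 nM.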

Compound 3, half-maximal inhibitory concentration: 18200 nM
The estimate for compound 3 lay 1.0-fold (0.00 log units) below the measured number; low and high end bracket the measured number.
By their numbers in this assay, from the lowest: compounds 2, 3 and 1 (each within the scatter of the next).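

In this assay, the exchange gives a 1.0-fold lower number from compound 1 to compound 3 (0.00 log units; within the scatter), so at this place, on an aromatic carbon para to a large group, the number does not separate methoxy from tert-butyl. The earlier step only added a second methoxy to the ring, so every ring substituent measured until now contained oxygen, whereas tert-butyl has 4 carbon atoms and no hydrogen-bond acceptor, and compound 3 still lies within the scatter of compound 1; for this one pair, then, the oxygen of the methoxy group is not needed to hold the number at this level. No measurement of any property of these groups is at hand to account for this result.

As far as these compounds go, whether an amine or a carboxylic acid at the same place would also stay within the scatter remains open, since methoxy and tert-butyl alone say little about groups of other kinds. The fluorinated aromatic ring and the methyl group on the nitrogen of the core stay the same in all the compounds shown, so what a change at either of those places would do is open as well.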